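This account rests on a few compounds, and the source may have more. Where it says the series, first, only, none or still open, it means among the compounds named here.

Going by the values given here, compound 2 `COc1ccc2c(=O)c(/C=C/C(=O)Nc3cc(C)ccc3C)coc2c1` stands apart among the three measured compounds: in a functional assay on A549 cells (Homo sapiens) for inhibition, read by MTT assay, with a stated time of 48 h (on this read-out higher numbers stand for weaker inhibition and lower numbers for stronger inhibition), compound 2 gives 15500 nM, the only value shown as a number. Compound 1 `O=C(/C=C/c1coc2cc(O)ccc2c1=O)NCc1ccc(F)cc1` gives only a limit of this assay, > 100000 nM. Compound 3 `O=C(/C=C/c1coc2cc(O)ccc2c1=O)NCc1ccccc1` likewise gives only a limit, > 100000 nM. Among the compounds with values here, the one measured step, a step that the two limits leave unreadable from compound 1 to compound 3, cannot be read, because both ends sit at the limit of > 100000 nM in this assay, at which 2 of the 3 values shown sit.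

Compound 4 `CCOc1ccc(NC(=O)/C=C/c2coc3cc(OC)ccc3c2=O)cc1` differs from compound 2 by one change: 4-ethoxyphenyl in place of 2,5-dimethylphenyl on an amide-type nitrogen. Within the data shown here, no measured step touches this part of the molecule, so no size or direction of change can be drawn from it, and a step within the scatter is expected. Compound 4 is therefore estimated at 15000 nM, between 5000 nM and 50000 nM, a step of a 1.0-fold lower number from compound 2 to compound 4 (0.01 log units; within the scatter).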

Compound 4, half-maximal inhibitory concentration: > 100000 nM
Compound 4 was reported as a limit; the forecaster's own chance of this, stated with the estimate: 20%; middle value at least 6.6-fold (0.82 log units) from the limit.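

Swapping 2,5-dimethylphenyl for 4-ethoxyphenyl on the amide-type nitrogen gives an at least 6.4-fold higher number from compound 2 to compound 4 (0.80 log units; beyond the scatter), the first readable step here, and it shows that inhibition in this assay depends on the group at this position. Going by these compounds, the result for compound 4 is a limit, not a number, so the full size of the step stays unknown. Only compound 2 has a number, and the others sit at a limit: the limit of > 100000 nM in this assay, at which 3 of the 4 values shown sit.

On these data alone, this one change replaces the two methyl groups and adds the ethoxy group together, so the effect of each alone stays open. As far as these compounds go, how an amine or a carboxylic acid on this phenyl ring would read also stays open.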